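Fluoroethoxy for Methoxy: Reading One Pair From Another

The source may hold more compounds than are shown below. What is called first, only, known or untested is meant among the compounds shown, and "the series" means these compounds.

Three compounds have been measured in an assay on membranes from brain for displacement of a labelled ligand from Sigma non-opioid intracellular receptor 1 (Cavia porcellus), read by scintillation counting, with a stated time of 90 min; on this read-out higher numbers stand for weaker inhibition and lower numbers for stronger inhibition:

compound 1, `COc1cccc(Cn2cc(C(=O)NCCCCN3CCc4cc(OC)c(OC)cc4C3)nn2)c1`: 12700 nM
compound 2, `COc1cc2c(cc1OC)CN(CCCCNC(=O)c1cn(Cc3cccc(OCCF)c3)nn1)CC2`: 46300 nM
compound 3, `COc1cc2c(cc1OC)CN(CCCCNC(=O)c1cc(-n3cc(CN(C)C)nn3)ccc1OC)CC2`: 22400 nM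

Compound 1 and compound 2 differ by one change, (fluoromethyl in place of hydrogen on a saturated chain carbon bound to an oxygen on an aromatic ring), and the step is a 3.6-fold higher number from compound 1 to compound 2 (0.56 log units; beyond the scatter). Compound 3 shares the amine end with compound 1 but the difference between the two cores is not broken down here; its number lies within the scatter of compound 1 and beyond that of compound 2.

Compound 4, `COc1cc2c(cc1OC)CN(CCCCNC(=O)c1cc(-n3cc(CN(C)C)nn3)ccc1OCCF)CC2`, is compound 3 carrying the same change, (fluoromethyl in place of hydrogen on a saturated chain carbon bound to an oxygen on an aromatic ring), at the same place. Because the measured pair gave a 3.6-fold higher number from compound 1 to compound 2 (0.56 log units; beyond the scatter), compound 4 is expected to show a step of about a 3.1-fold higher number from compound 3 to compound 4 (0.49 log units; beyond the scatter) in this assay, on the basis of that single precedent only. Compound 4 is therefore estimated at 70000 nM, likely between 25000 nM and 200000 nM.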

Compound 4, inhibition constant: 21900 nM
Compound 4: the middle estimate sits 3.2-fold (0.50 log units) above what was measured, outside the stated range (below it).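

In this assay, the change from methoxy to 2-fluoroethoxy gives a 1.0-fold lower number from compound 3 to compound 4 (0.01 log units; within the scatter), so on this core it makes no difference beyond the scatter. The step seen on the core of compound 1 therefore does not carry over to the core of compound 3: the same change on two cores in this assay, a 3.6-fold higher number (0.56 log units; beyond the scatter) from compound 1 to compound 2 and a 1.0-fold lower number (0.01 log units; within the scatter) from compound 3 to compound 4, 3.7-fold (0.57 log units) apart, beyond the scatter of two such steps

These two pairs show that the size of the step depends on the core, but they do not show which part of the core matters, why it matters, or what the change would do on a further core. The compounds shown leave open whether a longer chain, such as fluoropropoxy, would follow either pair. They also leave open whether a hydroxyl group at the same place would do so.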